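Ester variants on a shared core: growth inhibition notes

The source may report more compounds than this note shows. Statements on the series, on what has been measured and on what is new or still open speak of the compounds shown alone.

Measured so far:
compound 1 `CC(C)[C@H](N)C(=O)OCCCOC1(c2ccc(Cl)cc2)c2ccccc2C(=O)N1Cc1ccccc1` — 20000 nM
compound 2 `CC(C)(CO)COC1(c2ccc(Cl)cc2)c2ccccc2C(=O)N1Cc1ccc(Cl)cc1` — 50000 nM

In a functional assay on HCT-116 cells (Homo sapiens) for inhibition, read by fluorescence, with a stated time of 48 h (a higher number here means a weaker inhibitor of growth, a lower number a stronger inhibitor of growth), compound 1 gives 20000 nM, the lower of the two numbers in hand. In this assay compound 2 gives 50000 nM, a higher number and beyond the usual scatter, so compound 1 is the stronger inhibitor of growth of the pair; the two differ in more than one place, so no single change is tied to that gap.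

Compound 3 `CC(=O)OCC(C)(C)COC1(c2ccc(Cl)cc2)c2ccccc2C(=O)N1Cc1ccccc1` is not yet measured. It differs from compound 1 in one place: 1-(acetoxymethyl)-1-methylethyl in place of 2-(((1-amino-2-methylpropyl)carbonyl)oxy)ethyl on a saturated chain carbon bound to an oxygen on a saturated carbon. Among the compounds with values here, no step between measured compounds touches this position, so nothing measured speaks to the change directly. Both measured numbers are weak, and the expectation is a step from compound 1 to compound 3 of a 1.3-fold higher number from compound 1 to compound 3 (0.10 log units; within the scatter), no more than the scatter, in either direction. Compound 3 is estimated at 25000 nM, within 8000 nM to 70000 nM.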

Compound 3, concentration for 50% growth inhibition: 38000 nM
Compound 3: middle estimate off by 1.5-fold (0.18 log units), on the low side; low and high end bracket the measured number.
By their numbers in this assay, from the lowest: compounds 1, 3 and 2 (each within the scatter of the next, the first and the last beyond it).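

In this assay, within the data shown here, 1-(acetoxymethyl)-1-methylethyl in place of 2-(((1-amino-2-methylpropyl)carbonyl)oxy)ethyl on a saturated chain carbon bound to an oxygen on a saturated carbon gives a 1.9-fold higher number from compound 1 to compound 3 (0.28 log units; within the scatter), the first direct reading at this position. The entering group has no nitrogen, hydrogen-bond donor or defined stereocentre, yet this exchange does not separate the two compounds beyond the usual scatter, so this single pair ties none of those features to growth inhibition. No measurement in hand bears on a cause for this result.

Open, going by these compounds, is whether a carboxylic acid or a longer chain at this position would give a step beyond the scatter. Also open, on these data alone, is what a hydroxyl in place of the acetoxy group does on its own, since compound 2 differs from compound 3 in more than one place.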